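Amide side chains on the shared core: toward compound 3

The source may report more compounds than this note shows. Statements on the series, on what has been measured and on what is new or still open speak of the compounds shown alone.

Of the compounds shown here, two have been measured in an assay (Ovis aries) for binding affinity to melatonin receptor type 1A (Homo sapiens); a higher number here means a weaker inhibitor, a lower number a stronger inhibitor. Compound 1 `COc1ccc2cccc(C3CNC(=O)C3)c2c1` gives 1580 nM. Compound 2 `CNC(=O)c1cccc2ccc(OC)cc12` gives 1260 nM. Within the data shown here, that is the lowest of the two numbers, and the nearest to it is compound 1; the single measured step, a 1.3-fold lower number from compound 1 to compound 2 (0.10 log units; within the scatter), stays within the scatter, so the two compounds stand level in this assay.

Compound 3 `COc1ccc2cccc(CCC(N)=O)c2c1` has not been measured. Against compound 2 the change is 2-carbamoylethyl in place of methylcarbamoyl on an aromatic carbon. The amide function is kept but sits on a longer chain, attached at the same aromatic carbon.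

Among the measured compounds shown here, no measured step covers this exact change. For the measured compounds named here, the only step available, a 1.3-fold lower number from compound 1 to compound 2 (0.10 log units; within the scatter), exchanged one amide-bearing group for another at the same place and moved the number only within the scatter. On that basis a small step is expected in this assay, with no clear direction. Compound 3 is therefore expected near 900 nM, with a range from 300 nM to 3000 nM. The implied step, a 1.4-fold lower number from compound 2 to compound 3 (0.15 log units; within the scatter), is expected to stay within the scatter.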

Compound 3, half-maximal inhibitory concentration: 1000 nM
Estimate against measurement, compound 3: 1.1-fold (0.05 log units) below, and the stated range covers the measured number.
By their numbers in this assay, from the lowest: compounds 3, 2 and 1 (each within the scatter of the next).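

Working notes on the aromatic carbon that carries the side chain. In this assay, 2-carbamoylethyl in place of methylcarbamoyl gives a 1.3-fold lower number from compound 2 to compound 3 (0.10 log units; within the scatter), so lengthening the chain while keeping the amide function leaves the number level with that of compound 2, and the amide need not sit directly on the aromatic carbon for the number to stay there. The open 2-carbamoylethyl chain in place of 5-oxopyrrolidin-3-yl gives a 1.6-fold lower number from compound 1 to compound 3 (0.20 log units; within the scatter), so at this place the three amide-bearing groups now stand level, whether the amide is attached directly, through a chain or within the 5-oxopyrrolidin-3-yl group. Nothing at hand bears on the reason for this level picture.

Open, on these data alone, is whether the same picture holds for side chains without an amide at this aromatic carbon, such as an amine or a carboxylic acid, or for a longer chain such as 3-carbamoylpropyl. Every step among the three compounds stays within the scatter, and whether any change at this place can move the number beyond it remains unsettled.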